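The source may report more compounds than this note shows. Statements on the series, on what has been measured and on what is new or still open speak of the compounds shown alone.

Measured compounds:
compound 1 `CN(C)c1ncnc2c1ncn2C` — 33%
compound 2 `C[C@@H](c1ccccc1)n1cnc2c(N(C)C)ncnc21` — 33%
compound 3 `CN(c1ncnc2c1ncn2Cc1ccccc1)C1CCCC1` — 17%

In a functional assay on the whole organism for inhibition, with Rattus norvegicus as the target, in the maximal electroshock model, at a dose of 25 mg/kg by the intraperitoneal route (on this read-out lower numbers stand for less inhibition and higher numbers for more inhibition at the one dose given (going by the name of the read-out)), compound 1 gives 33%, compound 2 gives 33% and compound 3 gives 17%. Compound 3 stands lowest of the three numbers; its nearest neighbour, compound 1, lies beyond the scatter above it, and compound 2 lies the same distance above it. Compound 4 `Oc1ncnc2c1ncn2Cc1ccccc1` has not yet been measured in this assay. Within the data shown here, it differs from compound 3 in one place: hydroxy in place of cyclopentyl(methyl)amino on an aromatic carbon No measured pair shows this change, so its size is unknown from the series. With compound 3 already at 17%, the step from compound 3 to compound 4 is expected to be small and probably none beyond the scatter, estimated as a number 2 percentage points lower from compound 3 to compound 4 (within the scatter). Compound 4 is thus estimated at 15%, expected within 0% to 35%.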

Compound 4, a percentage reported as inhibition, in the whole organism at one dose (the size of the read-out at that dose, not a potency): 17%
For compound 4 the middle estimate is 2 percentage points below the measured one; measured number inside the range.
By their numbers in this assay, from the lowest: compounds 3 and 4 (each within the scatter of the next); then compounds 1 and 2 (each within the scatter of the next).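

Hydroxy in place of cyclopentyl(methyl)amino on this aromatic carbon gives no change at the digits printed from compound 3 to compound 4 (within the scatter) in this assay. Among these compounds, at this position, on this pair alone, the read-out does not separate a substituent with a five-membered carbon ring from a single oxygen-linked group, which no earlier pair could show. No measurement shown here offers an explanation for this. The compounds shown leave open whether a primary amine, chlorine or a methoxy group at this position would read apart from compound 3 and compound 4. Also open, as far as these compounds go, is whether dimethylamino there would differ with the rest of compound 4 held constant.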